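Working notes: pentyl to dimethylamino on a shared core

The compounds below may be only part of what the source reports. "The series", "measured", "known", "first", "only" and "open" are said of these compounds alone.

Compound 1 `c1ccc(Cn2c(-c3ccccc3)cc3ccccc32)cc1` and compound 2 `CCCCCc1ccc(-c2cc3ccccc3[nH]2)cc1` carry the same core with different substituents. In an assay on isolated protein for inhibition of Aromatase (Homo sapiens), read by fluorescence, using NADPH, with a stated time of 30 min, tested at 50 uM (a higher number here means more inhibition at the concentration tested (going by the name of the read-out), a lower number less inhibition), compound 1 gives 0%. Compound 2 gives 0% in this assay, level with compound 1 at the digits shown, the two together the lowest of the three readings. Compound 3 `O=[N+]([O-])c1ccc2[nH]c(-c3ccc(Cl)c(Cl)c3)cc2c1` gives 7.59% in this assay; its gap to compound 2 lies within the scatter, so the three measured compounds cannot be told apart on these numbers.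

Compound 4 `CN(C)c1ccc(-c2cc3ccccc3[nH]2)cc1` has not been measured. It differs from compound 2 in one place: dimethylamino in place of pentyl on an aromatic carbon. Going by the values given here, no step between measured compounds is available here to gauge the effect of this change, and all three readings sit close to zero. The step from compound 2 to compound 4 in this assay is therefore expected to be a number 5 percentage points higher from compound 2 to compound 4 (within the scatter), none beyond the scatter. For compound 4 the estimate in this assay is 5%, with a range from 0% to 20%.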

Compound 4, a percentage reported as inhibition, at one concentration (the size of the read-out at that concentration, not a potency): 0%
The estimate for compound 4 lay 5 percentage points above the measured number; the range from low to high includes it.
By their numbers in this assay, from the lowest: compounds 1, 2, 4 and 3 (each within the scatter of the next).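

Going by these compounds alone, the step of no change at the digits printed from compound 2 to compound 4 (within the scatter) in this assay gives the first direct reading at this position, where the earlier compounds offered no step at all. Replacing the carbon-only pentyl chain with dimethylamino, which brings a nitrogen and a hydrogen-bond acceptor to this aromatic carbon, leaves the two compounds indistinguishable at the concentration tested. Nothing measured here offers an explanation for this result.

As far as these compounds go, it remains open whether any other group on this aromatic carbon, such as a carboxylic acid, a primary amine or a longer chain like octyl, would separate from pentyl and dimethylamino. Readings at a single concentration also leave open whether compound 2 and compound 4 differ in potency, which only a concentration series could show.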